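Replacing Dipropylamino with a Piperidinylethyl Amine

This account rests on a few compounds, and the source may have more. Where it says the series, first, only, none or still open, it means among the compounds named here.

Three compounds have been measured in an assay on HEK293 cells for inhibition of Steryl-sulfatase (Homo sapiens), tested at 0.1 uM; on this read-out higher numbers stand for a stronger effect at the one concentration tested and lower numbers for a weaker effect:

Compound 1 `CN(CCN1CCCCC1)c1ccc(C(=O)N2CCc3ccc(OS(N)(=O)=O)cc3C2)cc1` gives 0.3%
Compound 2 `CCCN(CCC)c1ccc(C(=O)N2CCc3ccc(OS(N)(=O)=O)cc3C2)cc1` gives 36.6%
Compound 3 `CCCN(CCC)c1cccc(C(=O)N2CCc3ccc(OS(N)(=O)=O)cc3C2)c1` gives 8.3%

Compound 2 and compound 3 are built from the same atoms joined differently; the difference between the two cores is not broken down here. From compound 2 to compound 1 the change is methyl(2-(piperidin-1-yl)ethyl)amino in place of dipropylamino on an aromatic carbon, and it produced a number 36.3 percentage points lower from compound 2 to compound 1 (beyond the scatter). Compound 4 `CN(CCN1CCCCC1)c1cccc(C(=O)N2CCc3ccc(OS(N)(=O)=O)cc3C2)c1` carries the same kind of change relative to compound 3, (methyl(2-(piperidin-1-yl)ethyl)amino in place of dipropylamino on an aromatic carbon), the group now sitting meta to a large group rather than para to a large group. Little room remains for a drop of similar size because compound 3 already gives 8.3%. The step this implies is expected to be a number 7.3 percentage points lower from compound 3 to compound 4 (within the scatter). Compound 4 is therefore estimated at 1%, with a range from -5% to 8%.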

Compound 4, a percentage reported as inhibition, at one concentration (the size of the read-out at that concentration, not a potency): 24.5%
Estimate against measurement, compound 4: 23.5 percentage points below; the measured number lies above the stated range.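

Placed meta to a large group, methyl(2-(piperidin-1-yl)ethyl)amino in place of dipropylamino gave a number 16.2 percentage points higher from compound 3 to compound 4 (beyond the scatter) in this assay. The change therefore does not carry from one core to the other as a fixed step, either in size or in direction: the same change on two cores in this assay, a number 36.3 percentage points lower (beyond the scatter) from compound 2 to compound 1 and a number 16.2 percentage points higher (beyond the scatter) from compound 3 to compound 4, 52.5 percentage points apart, beyond the scatter of two such steps

This rests on a single pair on each core, and it does not show why the two steps differ or how any other amine would behave.

The compounds shown leave open whether a morpholine in place of the piperidine would follow the same split between the two cores. They also leave open whether a longer chain between the two nitrogens would do so.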